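Swapping One Aromatic Group on a Four-Membered Ring

The source may hold more compounds than are shown below. What is called first, only, known or untested is meant among the compounds shown, and "the series" means these compounds.

In a functional assay on MCF7 cells (Homo sapiens) for antiproliferative activity, read by MTT assay, with stated times of 24 h and 72 h (a higher number here means a weaker inhibitor, a lower number a stronger inhibitor), compound 1 (`COc1cccc([C@@H]2[C@H](Oc3ccccc3)C(=O)N2c2cc(OC)c(OC)c(OC)c2)c1`) gives 171000 nM, and compound 2 (`COc1cc(N2C(=O)[C@@H](Oc3ccccc3)[C@H]2c2ccc([S+](C)[O-])cc2)cc(OC)c1OC`) gives 20000 nM, the lower and therefore stronger of the two numbers. The next structure, compound 3 (`COc1cc(N2C(=O)[C@@H](Oc3ccccc3)[C@H]2c2ccc(O)c(O)c2)cc(OC)c1OC`), keeps the rest of compound 2 and changes one group. A 3,4-dihydroxyphenyl group enters on a saturated ring carbon of the four-membered non-aromatic ring with 1 nitrogen, next to the ring atom that bears a phenoxy group: a group of 8 heavy atoms (6 carbon, 2 oxygen; one six-membered aromatic ring of carbon only) in place of a group of 9 heavy atoms (7 carbon, 1 oxygen, 1 sulfur; one six-membered aromatic ring of carbon only), on a saturated ring carbon.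

Going by the values given here, only one measured step bears on this change. It is an 8.6-fold lower number from compound 1 to compound 2 (0.93 log units; beyond the scatter), and it altered the group at this same place. That step shows that this assay can respond to a change here by more than the scatter. However, no measured compound carries the 3,4-dihydroxyphenyl group, so the data give no direction for the new swap. With no direction to go on, the expected change is small, a 1.3-fold higher number from compound 2 to compound 3 (0.10 log units; within the scatter), and not beyond the scatter, though real uncertainty remains in either direction. For compound 3 the estimated value is 25000 nM, with an expected range from 4000 nM to 120000 nM.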

Compound 3, half-maximal inhibitory concentration: 4500 nM
Compound 3: middle estimate off by 5.6-fold (0.74 log units), on the high side; low and high end bracket the measured number.
By their numbers in this assay, from the lowest: compound 3; then compound 2; then compound 1.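

In this assay, going by these compounds alone, the earlier step showed only that a change on this saturated ring carbon can move the number, while a 4.4-fold lower number from compound 2 to compound 3 (0.65 log units; beyond the scatter) now shows that the 3,4-dihydroxyphenyl group outperforms the sulfur-bearing group it replaces. Against the 3-methoxyphenyl group, the same swap gives a 38-fold lower number from compound 1 to compound 3 (1.58 log units; beyond the scatter), the largest step among these compounds, and the order from the lowest number runs compound 3, compound 2, compound 1, with each neighbouring step beyond the scatter. The 3,4-dihydroxyphenyl group carries hydrogen-bond donors where the sulfur-bearing group has none, but this is only a difference between the two structures, and no supporting measurement says why the number falls.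

The compounds shown leave open whether both hydroxyl groups are needed, and a phenyl ring with a single hydroxyl group, or with one hydroxyl group and one methoxy group, would test this directly. They also leave open how a phenyl ring bearing an amine or a carboxylic acid would compare at this place, and whether the lower number would hold with the phenoxy group on the neighbouring ring atom changed.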